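From a Thiophen-2-yl to a Pyridin-2-yl Substituent

The source may hold more compounds than are shown below. What is called first, only, known or untested is meant among the compounds shown, and "the series" means these compounds.

Compound 1 `Oc1ccc(-c2cc(-c3ccc(Cl)cc3)nc(-c3cccs3)c2)cc1` gives 6470 nM in a functional assay on HCT-15 cells (Homo sapiens) for cytotoxicity, read by CCK-8 assay and cell counting, with a stated time of 2 days (a higher number here means a weaker inhibitor, a lower number a stronger inhibitor), the highest of the two numbers in hand; compound 2 `Oc1ccc(-c2cc(-c3cccc(Cl)c3)nc(-c3cccs3)c2)cc1` gives 5050 nM, and the step of a 1.3-fold lower number from compound 1 to compound 2 (0.11 log units; within the scatter) lies within the scatter. Compound 3 `Oc1ccc(-c2cc(-c3ccc(Cl)cc3)nc(-c3ccccn3)c2)cc1` differs from compound 1 by pyridin-2-yl in place of thiophen-2-yl on an aromatic carbon. Going by the values given here, no measured step touches this position; the only step measured so far concerns another part of the molecule and stayed within the scatter. The account therefore expects for compound 3 a step of a 1.1-fold lower number from compound 1 to compound 3 (0.03 log units; within the scatter), none beyond the scatter. Compound 3 is estimated at 6000 nM, ranging from 2000 nM to 18000 nM.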

Compound 3, half-maximal inhibitory concentration: 21300 nM
The estimate for compound 3 lay 3.6-fold (0.55 log units) below the measured number, and the stated range ends below it.
By their numbers in this assay, from the lowest: compounds 2 and 1 (each within the scatter of the next); then compound 3.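

In this assay, this position proves sensitive to the ring it carries: pyridin-2-yl in place of thiophen-2-yl gives a 3.3-fold higher number from compound 1 to compound 3 (0.52 log units; beyond the scatter), a modest step but beyond the scatter, whereas the earlier change from 4-chlorophenyl to 3-chlorophenyl stayed within it. No measurement at hand bears on the reason for this step. The compounds shown leave open how a phenyl or furan-2-yl ring would fare at this position, and whether pyridin-2-yl would give a similar step alongside the 3-chlorophenyl group of compound 2.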